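This account rests on a few compounds, and the source may have more. Where it says the series, first, only, none or still open, it means among the compounds named here.

Compounds measured so far in a functional assay on NCI-H23 cells (Homo sapiens) for cytotoxicity, read by sulforhodamine B assay, with a stated time of 48 h, tested at 0.1 uM; a lower number here means a stronger effect, a higher number a weaker effect of the compound at the concentration tested:

Compound 1, `COc1cc(-c2cc(/C=C/C(=O)c3ccc(N)cc3)[nH]n2)cc(OC)c1OC`: 105%
Compound 2, `COc1cc(-c2cc(/C=C/C(=O)c3ccc(Cl)c(Cl)c3)[nH]n2)cc(OC)c1OC`: 92%

Within the data shown here, compound 2 stands as the lower of the two numbers in this assay, and the only measured step is the one that leads to it: a number 13 percentage points lower from compound 1 to compound 2 (beyond the scatter). Compound 3, `COc1ccc(C(=O)/C=C/c2cc(-c3cc(OC)c(OC)c(OC)c3)n[nH]2)cc1OC`, differs from compound 2 in one place: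

3,4-dimethoxyphenyl in place of 3,4-dichlorophenyl on a carbonyl carbon

Among the measured compounds shown here, no measured step exchanges a 3,4-dichlorophenyl for a 3,4-dimethoxyphenyl on a carbonyl carbon, so the step from compound 1 to compound 2 is the only one that bears on this change at all, and it concerns a different pair of groups. That step was modest in this assay, and both compounds sit near the level at which the compound shows little effect at the tested concentration. Compound 3 is therefore expected to remain near that level, with an estimated step of a number 6 percentage points higher from compound 2 to compound 3 (within the scatter). For compound 3 in this assay the estimate is 98%, expected to fall between 85% and 110%.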

Compound 3, a percentage reported as activity, at one concentration (the size of the read-out at that concentration, not a potency): 94%
Beside the measured number, compound 3's estimate is 4 percentage points above it; low and high end bracket the measured number.
By their numbers in this assay, from the lowest: compounds 2 and 3 (each within the scatter of the next); then compound 1.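

In this assay, putting 3,4-dimethoxyphenyl in place of 3,4-dichlorophenyl on a carbonyl carbon gives a number 2 percentage points higher from compound 2 to compound 3 (within the scatter), so this assay does not separate the two groups, although one carries oxygen and the other chlorine. Compared with 4-aminophenyl, the 3,4-dimethoxyphenyl group gives a number 11 percentage points lower from compound 1 to compound 3 (beyond the scatter), a modest step that joins a number 13 percentage points lower from compound 1 to compound 2 (beyond the scatter). Among these three compounds, then, the position on the carbonyl carbon shows one clear division: compound 1 has the highest number, while compound 2 and compound 3 cannot be ranked against each other.

All three readings come from a single tested concentration, so they leave open whether compound 2 and compound 3 would separate at another concentration, and they give no potency for any of the compounds. From the compounds shown here alone, it also remains open whether a different group on the carbonyl carbon, such as a carboxylic acid, a morpholine or a plain phenyl, would move the number further from compound 1 than the modest steps seen here. No information is available that explains these differences in the readings.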